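A few compounds are considered here, and "the series" means these few. Any claim that something is new, unique, unknown or untested is made for them only; others in the source may bear on it.

Measured compounds and their values: compound 1, `COC(=O)c1ccc(-c2cnc(C(=O)CCc3ccc(-c4ccccc4)cc3)o2)nc1`, gives 2.2 nM in an assay for inhibition of Fatty-acid amide hydrolase 1 (Rattus norvegicus); a higher number here means a weaker inhibitor, a lower number a stronger inhibitor; compound 2, `N#Cc1cccc(-c2cnc(C(=O)CCc3ccc(COc4ccccc4)cc3)o2)n1`, gives 0.56 nM in this assay; compound 3, `O=C(O)c1ccc(-c2cnc(CCCc3ccc(-c4ccccc4)cc3)o2)nc1`, gives 20000 nM in this assay.

Among these three numbers compound 1 holds the second highest. Compound 2 sits nearest to it, with a lower number, and compound 3 sits far away, with a much higher number. Compound 4, `NC(=O)c1ccc(-c2cnc(C(=O)CCc3ccc(-c4ccccc4)cc3)o2)nc1`, has not yet been measured. It differs from compound 1 in one place: amino in place of methoxy on a carbonyl carbon.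

Among the compounds with values here, no measured pair shows this change on its own, so its effect is unknown from these data. The step from compound 1 to compound 4 is expected to be small, in either direction, and probably not beyond the scatter. Compound 4 is therefore estimated at 3 nM, with a range from 0.8 nM to 12 nM, meaning an expected step of a 1.4-fold higher number from compound 1 to compound 4 (0.13 log units; within the scatter).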

Compound 4, inhibition constant: 1.3 nM
Beside the measured number, compound 4's estimate is 2.3-fold (0.36 log units) above it; low and high end bracket the measured number.
By their numbers in this assay, from the lowest: compound 2; then compounds 4 and 1 (each within the scatter of the next); then compound 3.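

In this assay, amino in place of methoxy on this carbonyl carbon gives a 1.7-fold lower number from compound 1 to compound 4 (0.23 log units; within the scatter) and so no real difference can be read between the methoxycarbonyl and carbamoyl groups. The position therefore accepts this exchange, which swaps a hydrogen-bond acceptor for a hydrogen-bond donor and shortens the group by one heavy atom, without a clear loss of inhibition. No measured evidence accounts for this result.

Still open, on these data alone, is whether larger groups on this carbonyl carbon, such as methylamino or dimethylamino, would also be accepted.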